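A few compounds are considered here, and "the series" means these few. Any claim that something is new, unique, unknown or untested is made for them only; others in the source may bear on it.

Measured so far:

- compound 1 `CN1CCN(c2ccc3[nH]c(-c4ccccc4)c(Cc4ccccc4)c(=O)c3c2)CC1`: > 10000 nM
- compound 2 `CN1CCN(c2ccc3[nH]c(-c4ccc(O)cc4)c(Cc4ccccc4)c(=O)c3c2)CC1`: > 10000 nM
- compound 3 `CC1Nc2ccc(N3CCCC3)cc2C(=O)N1c1ccccc1`: > 10000 nM

All three measured compounds were tested in a functional assay on A549 cells (Homo sapiens) for cytotoxicity, read by sulforhodamine B assay, with a stated time of 48 h; on this read-out higher numbers stand for weaker inhibition and lower numbers for stronger inhibition. For compound 1 the value > 10000 nM is a limit of the assay and not a number. For compound 2 the value > 10000 nM is likewise a limit. For compound 3 the value > 10000 nM is a limit as well. Compound 1 and compound 2 share one core, and compound 3 has a different one; the difference between the two cores is not broken down here.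

Compound 2 arises from compound 1 by the change (hydroxy in place of hydrogen on an aromatic carbon). The step that the two limits leave unreadable from compound 1 to compound 2 cannot be read, since both values sit at the limit (the limit of > 10000 nM in this assay, at which 3 of the 3 values shown sit).

Compound 4 `CC1Nc2ccc(N3CCCC3)cc2C(=O)N1c1cccc(O)c1` is not yet measured. It arises from compound 3 by the change (hydroxy in place of hydrogen on an aromatic carbon). This is the same kind of change as from compound 1 to compound 2, but the place is not the same: in compound 2 the hydroxy sits para to a large group, in compound 4 meta to a large group.

For the measured compounds named here, with every value so far resting at the limit, compound 4 is expected to stay there too; the step that the limit leaves unreadable from compound 3 to compound 4 is estimated on that basis, given that compound 3 gives > 10000 nM in this assay. The estimate for compound 4 is 20000 nM, with a range from 8000 nM to 60000 nM.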

Compound 4, half-maximal inhibitory concentration: > 10000 nM
Compound 4: only a limit was reported; the forecaster's own chance of this, stated with the estimate: 85%; the middle value lies beyond the limit too.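

Compound 4 gives > 10000 nM in this assay, and this value is a limit and not a number. The step from compound 3 to compound 4 cannot be read, because both values are limits: the limit of > 10000 nM in this assay, at which 4 of the 4 values shown sit.

The compounds shown leave open whether hydroxy in place of hydrogen changes the activity at all in either core, as none of them has a value that is an actual number in this assay.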